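This account rests on a few compounds, and the source may have more. Where it says the series, first, only, none or still open, it means among the compounds named here.

Measured so far in a functional assay on B16-F10 cells (Mus musculus) for antiproliferative activity, read by ELISA and MTT assay, with a stated time of 48 h; on this read-out higher numbers stand for weaker inhibition and lower numbers for stronger inhibition:

compound 1, `Cc1ccc(S(=O)(=O)NC(=O)/C=C/c2ccc(F)cc2)cc1`, gives 4.8 ug/mL
compound 2, `Cc1ccc(S(=O)(=O)NC(=O)/C=C/c2ccc(Cl)cc2)cc1`, gives 4.6 ug/mL
compound 3, `O=C(/C=C/c1ccccc1[N+](=O)[O-])NS(=O)(=O)c1ccc(F)cc1`, gives 6 ug/mL

Compounds 1 and 2 share a core and differ in one place: chloro in place of fluoro on an aromatic carbon. This change gave a 1.0-fold lower number from compound 1 to compound 2 (0.02 log units; within the scatter). Compound 3 is built on another core, and the difference between the two cores is not broken down here. In this assay compound 3 stands nearest to compound 1 and furthest from compound 2, and both gaps lie within the scatter, so no order among the three can be read from these numbers.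

Compound 4, `O=C(/C=C/c1ccccc1[N+](=O)[O-])NS(=O)(=O)c1ccc(Cl)cc1`, has not yet been measured. It carries the same change relative to compound 3 that compound 2 carries relative to compound 1: chloro in place of fluoro on an aromatic carbon. Both changes sit on an aromatic carbon of a six-membered aromatic ring of carbon only, para to a large group, so the two places read alike.

Because a 1.0-fold lower number from compound 1 to compound 2 (0.02 log units; within the scatter) stayed within the scatter, the step of a 1.1-fold lower number from compound 3 to compound 4 (0.03 log units; within the scatter) is also expected to stay small. Accordingly compound 4 is estimated at 5.6 ug/mL, with a likely range from 3 ug/mL to 11 ug/mL.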

Compound 4, half-maximal inhibitory concentration: 6.6 ug/mL
Estimate against measurement, compound 4: 1.2-fold (0.07 log units) below, and the stated range covers the measured number.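

In this assay, chloro in place of fluoro gave a 1.1-fold higher number from compound 3 to compound 4 (0.04 log units; within the scatter), so on the core of compound 3 the step stayed within the scatter, as it did on the core of compound 1. Set side by side, the two steps cannot be told apart: the same change on two cores in this assay, a 1.0-fold lower number (0.02 log units; within the scatter) from compound 1 to compound 2 and a 1.1-fold higher number (0.04 log units; within the scatter) from compound 3 to compound 4, 1.1-fold (0.06 log units) apart, within the scatter of two such steps. This shows that, on these two cores, the change carried over as a step too small to read; it does not show a shared direction, and two pairs in a single cell assay cannot establish that the change would stay this small on every core in the series.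

The compounds shown carry only fluoro or chloro at this place, so it remains open whether bromo, a methoxy group, an amine or a carboxylic acid there would give a step beyond the scatter. Also open, as far as these compounds go, is how the change from fluoro to chloro would read on a core other than these two.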